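Ring swap at the nitrogen-bound chain carbon

The source may hold more compounds than are shown below. What is called first, only, known or untested is meant among the compounds shown, and "the series" means these compounds.

Measured so far:
compound 1 `CCSc1nc2cc(S(=O)(=O)NCc3ccc(F)cc3)ccc2n1Cc1ccccc1` — 250 nM
compound 2 `CCOc1nc2cc(S(=O)(=O)NCc3ccc(F)cc3)ccc2n1Cc1cccc(Cl)c1` — 880 nM

In an assay on isolated protein for inhibition of Gonadotropin-releasing hormone receptor (Homo sapiens) (on this read-out higher numbers stand for weaker inhibition and lower numbers for stronger inhibition), compound 2 gives 880 nM, the highest of the two numbers shown. Compound 1 gives 250 nM, a lower number by a margin beyond the scatter, but compound 1 and compound 2 differ in more than one place, so their gap is not a single step. Compound 3 `CCOc1nc2cc(S(=O)(=O)NCc3ccc(F)cc3)ccc2n1Cc1ccsc1` carries thiophen-3-yl in place of 3-chlorophenyl on a saturated chain carbon bound to an aromatic nitrogen. Among the compounds with values here, no single-change step has been measured, so the step of a 1.1-fold higher number from compound 2 to compound 3 (0.06 log units; within the scatter) is expected to stay within the scatter, with no clear direction. Compound 3 is expected to give 1000 nM, in a range of 300 nM to 3500 nM.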

Compound 3, half-maximal inhibitory concentration: 1400 nM
The estimate for compound 3 lay 1.4-fold (0.15 log units) below the measured number; low and high end bracket the measured number.
By their numbers in this assay, from the lowest: compound 1; then compounds 2 and 3 (each within the scatter of the next).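

In this assay, within the data shown here, thiophen-3-yl in place of 3-chlorophenyl on a saturated chain carbon bound to an aromatic nitrogen gives a 1.6-fold higher number from compound 2 to compound 3 (0.20 log units; within the scatter) and so provides the first single-place reading at this position. In this pair, the five-membered aromatic ring with 1 hetero atom and the chlorine-bearing six-membered ring are not told apart. No measurement on hand bears on this result.

Still open, going by these compounds, is whether a basic amine or a carboxylic acid on this ring, or a longer chain in place of the methylene, would shift the number beyond the scatter.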